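Swapping Fluoro for Hydroxy on a Sulfonyl Aryl Ring

A few compounds are considered here, and "the series" means these few. Any claim that something is new, unique, unknown or untested is made for them only; others in the source may bear on it.

Of the compounds shown here, two sharing one core have growth-inhibition numbers so far: compound 1 `Cn1c(=O)c(S(=O)(=O)c2ccc(OC(=O)CCCCC3SCC4NC(=O)NC43)cc2)cc2cnc(Nc3ccc4[nH]ccc4c3)nc21` and compound 2 `Cn1c(=O)c(S(=O)(=O)c2ccc(F)cc2)cc2cnc(Nc3ccc4[nH]ccc4c3)nc21`. In a functional assay on SK-MEL-28 cells (Homo sapiens) for inhibition, read by trypan blue exclusion, with a stated time of 72 h (on this read-out lower numbers stand for stronger inhibition of growth and higher numbers for weaker inhibition of growth), compound 1 gives 500 nM and compound 2 gives 300 nM. Compound 2 therefore stands level with compound 1, the two values lying within the scatter of each other.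

The next compound to be tested is compound 3 `Cn1c(=O)c(S(=O)(=O)c2ccc(O)cc2)cc2cnc(Nc3ccc4[nH]ccc4c3)nc21`, which is compound 2 with one exchange: hydroxy in place of fluoro on an aromatic carbon. The hydroxy takes the place of the fluoro on an aromatic carbon, and the rest of the structure stays the same. Going by the values given here, no measured pair in this set shows what such an exchange does in this assay, so the data offer only a thin guide. The expectation rests on compound 2 at 300 nM and on the nearby compound 1 at 500 nM. No change beyond the scatter is expected, and the estimated 1.2-fold higher number from compound 2 to compound 3 (0.07 log units; within the scatter) has no firm direction. For compound 3 the expected value is 350 nM, with an estimated range of 120 nM to 1000 nM.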

Compound 3, concentration for 50% growth inhibition: 500 nM
Compound 3: the middle estimate sits 1.4-fold (0.15 log units) below what was measured; the range from low to high includes it.
By their numbers in this assay, from the lowest: compounds 2, 1 and 3 (each within the scatter of the next).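

In this assay, going by these compounds alone, the exchange of fluoro for hydroxy on an aromatic carbon para to a large group gives a 1.7-fold higher number from compound 2 to compound 3 (0.22 log units; within the scatter), and this is the first direct reading of a single change at this position. The step lies within the scatter, so this read-out does not separate the 4-fluorophenyl and 4-hydroxyphenyl compounds, even though the entering hydroxy counts a hydrogen-bond donor and a hydrogen-bond acceptor and the leaving fluoro counts neither. No measurement is available that bears on what lies behind this result.

Within the data shown here, this single pair leaves open how much room the position has, since it covers only two small groups of one heavy atom each, and a single step cannot show a trend. Whether an amine, a carboxylic acid, a methoxy group or a longer chain on the same aromatic carbon would stay level with compound 2 or move beyond the scatter cannot be told from the compounds shown here.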